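Replacing a phenoxy link with an anilino link

The compounds below may be only part of what the source reports. "The series", "measured", "known", "first", "only" and "open" are said of these compounds alone.

Measured so far in a functional assay on MCF7 cells (Homo sapiens) for antiproliferative activity; on this read-out higher numbers stand for weaker inhibition and lower numbers for stronger inhibition:
- compound 1 `COc1cccc(Oc2ccc3cc(NC(=O)c4ccc(OC(C)=O)c(CC=C(C)C)c4)c(=O)oc3c2C)c1` gives 15700 nM
- compound 2 `COc1cccc(Oc2ccc3cc(NC(=O)c4ccc(OC)c(-c5cccc(OC)c5)c4)c(=O)oc3c2C)c1` gives only the assay limit > 100000 nM
- compound 3 `COc1ccc(Nc2ccc3cc(NC(=O)c4ccc(OC(C)=O)c(CC=C(C)C)c4)c(=O)oc3c2C)cc1` gives only the assay limit > 100000 nM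

Compound 2 stands at the limit of this assay, with no number below it; it shares that position with compound 3, as two of the three values sit at the limit of > 100000 nM in this assay, at which 2 of the 3 values shown sit. The unmeasured compound 4 `COc1ccc(Nc2ccc3cc(NC(=O)c4ccc(OC)c(-c5cccc(OC)c5)c4)c(=O)oc3c2C)cc1` differs from compound 2 in one place: (4-methoxyphenyl)amino in place of 3-methoxyphenoxy on an aromatic carbon.

The same change has been measured once, on a different right-hand part, as an at least 6.3-fold higher number from compound 1 to compound 3 (0.80 log units; beyond the scatter). That step moved a measured number up to the limit. Applied to compound 2, which already sits at the limit, the change offers no route to a stronger inhibition; the expectation is that compound 4 will also give only the limit, so the step that the limit leaves unreadable from compound 2 to compound 4 is expected to be unresolved rather than measured. Compound 4 is therefore estimated at 200000 nM, within 100000 nM to 1000000 nM, most likely reported as a limit.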

Compound 4, half-maximal inhibitory concentration: > 100000 nM
Compound 4 gave a limit, no number; the forecaster's own chance of this, stated with the estimate: 90%; the middle value lies beyond the limit too.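

For the compounds shown here, compound 2 and compound 4 both gave only a limit, not a number, so no step between them can be read: the limit of > 100000 nM in this assay, at which 3 of the 4 values shown sit.

On these data alone, what replacing 3-methoxyphenoxy with (4-methoxyphenyl)amino does to inhibition, on the right-hand part shared by compound 2 and compound 4, remains open.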